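The compounds below may be only part of what the source reports. "The series", "measured", "known", "first", "only" and "open" are said of these compounds alone.

Among the compounds with values here, only two compounds with this core have been tested so far in a functional assay on SH-SY5Y cells (Homo sapiens) for antiproliferative activity, read by MTT assay, with a stated time of 48 h; a higher number here means a weaker inhibitor of growth, a lower number a stronger inhibitor of growth. Compound 1 `COc1ccc(N(C)c2nc(Cl)nc3[nH]cnc23)cc1`, which has a hydrogen on an aromatic nitrogen, reads > 100000 nM, and this is a limit of the assay and not a number. Within the data shown here, compound 2 `COc1ccc(N(C)c2nc(Cl)nc3c2ncn3C)cc1`, which has a methyl on that nitrogen, gives 3400 nM, the only true number so far.

Compound 3 `COc1ccc(N(C)c2nc(Cl)nc3c2ncn3Cc2cc(OC)cc(OC)c2)cc1` builds on the methyl of compound 2. The change is 3,5-dimethoxyphenyl in place of hydrogen on a saturated chain carbon bound to an aromatic nitrogen.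

Among the measured compounds shown here, only one measured step bears on this change, as it concerns the same aromatic nitrogen, and it was large: an at least 29-fold lower number from compound 1 to compound 2 (1.46 log units; beyond the scatter). That step replaced a hydrogen with a methyl, however, and it shows only that filling this nitrogen gave a stronger inhibitor of growth. It gives no measure of what a much larger group will do, so the expected direction is only tentatively towards a lower number. The expected change is a 1.7-fold lower number from compound 2 to compound 3 (0.23 log units; within the scatter), which is not expected to lie beyond the scatter. For compound 3 the estimate is 2000 nM, with an expected range from 300 nM to 15000 nM.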

Compound 3, concentration for 50% growth inhibition: > 100000 nM
Compound 3 was reported as a limit; the forecaster's own chance of this, stated with the estimate: 10%; at least 50-fold (1.69 log units) between middle value and limit.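

In this assay compound 3 gives > 100000 nM, which is a limit of the assay and not a number. Putting 3,5-dimethoxyphenyl in place of hydrogen on the saturated chain carbon bound to the aromatic nitrogen gives an at least 29-fold higher number from compound 2 to compound 3 (1.46 log units; beyond the scatter), so the growth inhibition seen with the methyl does not survive this much larger group. The earlier step showed only that a methyl on this nitrogen gives a stronger inhibitor of growth than a hydrogen; this result adds that the position does not accept every group, and that compound 1 and compound 3 cannot be ordered against each other, as both end at the same edge of what the assay reads: the limit of > 100000 nM in this assay, at which 2 of the 3 values shown sit.

The compounds shown do not tell whether the loss goes with the added ring itself or with its two methoxy groups, and an ethyl or an unsubstituted benzyl on this nitrogen would separate those readings. As far as these compounds go, how much weaker compound 3 truly is also stays unknown, as the step gives only a minimum.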